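1,3-Oxazol-5-yl to Furan-2-yl: an Untested Cytotoxicity Step

The source may report more compounds than this note shows. Statements on the series, on what has been measured and on what is new or still open speak of the compounds shown alone.

Compound 1 `N#Cc1cccc(C(=O)N2CCCC(C(=O)Nc3ccc(Cl)cc3)C2)c1` gives 0% in an ADME assay on PC-3 cells (Homo sapiens) for cytotoxicity, read by WST assay, tested at 100 uM; a lower number here means less inhibition, a higher number more inhibition at the concentration tested (going by the name of the read-out).
Compound 2 `O=C(Nc1cccc(-c2cnco2)c1)C1CCCN(C(=O)c2cc(C(F)(F)F)cc(C(F)(F)F)c2)C1` gives 9% in this assay.
Compound 3 `CS(=O)(=O)Nc1cccc(C(=O)N2CCCC(C(=O)Nc3ccc(Cl)cc3)C2)c1` gives 3% in this assay.

All three measured numbers sit close together. Compound 2 is nearest to compound 3 and furthest from compound 1, yet both gaps lie within the scatter, so compound 2 is not separated from either of them. Going by the values given here, the only single-point step measured so far runs a number 3 percentage points higher from compound 1 to compound 3 (within the scatter), with methanesulfonamido in place of cyano on an aromatic carbon; it stays within the scatter and touches a different part of the molecule.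

Compound 4 `O=C(Nc1cccc(-c2ccco2)c1)C1CCCN(C(=O)c2cc(C(F)(F)F)cc(C(F)(F)F)c2)C1` is the untested member. It differs from compound 2 by furan-2-yl in place of 1,3-oxazol-5-yl on an aromatic carbon. Among the compounds with values here, no measured step changes this position, so the expectation rests on the flat picture of compounds 1, 2 and 3 and on the small size of the exchange. A step of no change at the digits printed from compound 2 to compound 4 (within the scatter) is expected, which is none beyond the scatter. Compound 4 is estimated at 9% in this assay, within a range from 0% to 22%.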

Compound 4, a percentage reported as inhibition, at one concentration (the size of the read-out at that concentration, not a potency): 0%
Compound 4: middle estimate off by 9 percentage points, on the high side; the range from low to high includes it.
By their numbers in this assay, from the lowest: compounds 1, 4, 3 and 2 (each within the scatter of the next).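

Going by these compounds alone, with furan-2-yl in place of 1,3-oxazol-5-yl on this aromatic carbon, this assay reads a number 9 percentage points lower from compound 2 to compound 4 (within the scatter) and so gives the first measured step at this position. Compound 4 is therefore not separated from compound 2, and the exchange of these two five-membered aromatic rings joins the step from compound 1 to compound 3 in staying within the scatter, though at a different place on the molecule. No measurement shown offers an explanation for this result.

The compounds shown leave open whether a group of another kind on this aromatic carbon, such as an amine, a carboxylic acid or a longer alkyl chain, would give a step beyond the scatter. They also leave open whether furan-2-yl and 1,3-oxazol-5-yl would read alike on the core of compound 1.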